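The source may hold more compounds than are shown below. What is called first, only, known or untested is meant among the compounds shown, and "the series" means these compounds.

In a functional assay on U-251 cells (Homo sapiens) for inhibition, read by sulforhodamine B assay, with a stated time of 48 h (a lower number here means a stronger inhibitor of growth, a higher number a weaker inhibitor of growth), compound 1 (`CCCc1ccc(C2NC(=S)NC(C)=C2C(=O)OCC)cc1`) gives 29.2 ug/mL and compound 2 (`CCOC(=O)C1=C(C)NC(=O)NC1c1ccc(O)c(O)c1`) gives 0.25 ug/mL as the lower of the two numbers, a gap beyond the scatter. Compound 3 (`CCOC(=O)C1=C(C)NC(=O)NC1c1ccc(O)cc1`) departs from compound 2 by one change (hydrogen in place of hydroxy on an aromatic carbon): hydrogen in place of hydroxy on an aromatic carbon, ortho to a hydroxy group. Among the measured compounds shown here, no measured pair shows this change alone, so its size remains a judgement. A step toward weaker inhibition of growth in this assay is expected, beyond the scatter. The estimated step is a 16-fold higher number from compound 2 to compound 3 (1.20 log units; beyond the scatter) and points to a higher number. For compound 3 the estimated value is 4 ug/mL with a range from 0.6 ug/mL to 30 ug/mL expected.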

Compound 3, concentration for 50% growth inhibition: 4.2 ug/mL
For compound 3 the middle estimate is 1.1-fold (0.02 log units) below the measured one, and the stated range covers the measured number.
By their numbers in this assay, from the lowest: compound 2; then compound 3; then compound 1.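

In this assay, among the compounds shown here, hydrogen in place of hydroxy on the aromatic carbon ortho to a hydroxy group gives a 17-fold higher number from compound 2 to compound 3 (1.23 log units; beyond the scatter), the first step that isolates one place. This position is therefore not indifferent: the hydroxy group there matters for growth inhibition, and the remaining hydroxy group does not make up for its loss. Nothing measured here accounts for the size of this step. Open, as far as these compounds go, is whether hydroxy itself is needed at this place, which a methoxy group, fluorine or an amine on the same carbon would test. Also open, from the compounds shown here alone, is what the remaining hydroxy group contributes on its own.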